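Working notes: chain extension from compound 1 to compound 4

The source may hold more compounds than are shown below. What is called first, only, known or untested is meant among the compounds shown, and "the series" means these compounds.

Compound 1 `COc1cc2ncnc(Nc3ccc(B(O)O)cc3)c2cc1OC` stands only on a limit in the numbers shown. In an assay on isolated protein for inhibition of vascular endothelial growth factor receptor 1 (Homo sapiens), read by ELISA, with a stated time of 20 min (on this read-out lower numbers stand for stronger inhibition and higher numbers for weaker inhibition), compound 1 gives > 1000 nM, which is a limit of the assay and not a number. Compound 2 `OB(O)c1ccc2ncnc(Nc3cccc(Cl)c3)c2c1` gives > 1000 nM in this assay, likewise a limit. Compound 3 `COc1cc2ncnc(Nc3cccc(Cl)c3)c2cc1B(O)O` gives > 1000 nM in this assay, again a limit. Among the measured compounds shown here, the single traced step, a step that the two limits leave unreadable from compound 2 to compound 3, is therefore of unreadable size. All three values sit at the limit of > 1000 nM in this assay, at which 3 of the 3 values shown sit, so compound 1 cannot be placed above or below compound 2 or compound 3.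

Compound 4 `COCCOc1cc2ncnc(Nc3ccc(B(O)O)cc3)c2cc1OC` is not yet measured. It differs from compound 1 by methoxymethyl in place of hydrogen on a saturated chain carbon bound to an oxygen on an aromatic ring. For the measured compounds named here, no measured step bears on this change: the only traced step, a step that the two limits leave unreadable from compound 2 to compound 3, gives no readable size and concerns a different group. Compound 4 is expected to stay at the limit, so the step that the limit leaves unreadable from compound 1 to compound 4 is estimated to be of no readable size. The estimate for compound 4 is 3000 nM, with a range from 800 nM to 20000 nM.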

Compound 4, half-maximal inhibitory concentration: > 1000 nM
Compound 4 ended at the assay's limit; the forecaster's own chance of this, stated with the estimate: 80%; the middle value lies beyond the limit too.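

No step can be read from compound 1 to compound 4, as both values are limits and not numbers: the limit of > 1000 nM in this assay, at which 4 of the 4 values shown sit.

The compounds shown leave open how strongly any of the four inhibits, and whether methoxymethyl in place of hydrogen changes inhibition at all.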